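Methoxy for hydrogen on compound 1

The source may hold more compounds than are shown below. What is called first, only, known or untested is meant among the compounds shown, and "the series" means these compounds.

Compound 1 `COc1ccc(C(=O)/C=C/c2cc(-c3cc(OC)c(OC)c(OC)c3)n[nH]2)cc1OC` in a functional assay on OVCAR-3 cells (Homo sapiens) for cytotoxicity, read by sulforhodamine B assay, with a stated time of 48 h, tested at 0.01 uM (on this read-out higher numbers stand for a weaker effect at the one concentration tested and lower numbers for a stronger effect), gives 100%; this is the lower of the two numbers seen, though compound 2 `COc1cc(-c2cc(/C=C/C(=O)c3ccc(F)c(F)c3)[nH]n2)cc(OC)c1OC` at 102% lies within the scatter of it. For the measured compounds named here, the one measured step, a number 2 percentage points higher from compound 1 to compound 2 (within the scatter), changes the group on the carbonyl carbon. Compound 3 `COc1cc(C(=O)/C=C/c2cc(-c3cc(OC)c(OC)c(OC)c3)n[nH]2)cc(OC)c1OC` differs from compound 1 by methoxy in place of hydrogen on an aromatic carbon. Going by the values given here, no measured step covers a methoxy for hydrogen, and the single step known stays within scatter, so in this assay the step is expected to be no change at the digits printed from compound 1 to compound 3 (within the scatter). Compound 3 is therefore estimated at 100%, with a range of 90% to 110%.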

Compound 3, a percentage reported as activity, at one concentration (the size of the read-out at that concentration, not a potency): 107%
Beside the measured number, compound 3's estimate is 7 percentage points below it; low and high end bracket the measured number.
By their numbers in this assay, from the lowest: compounds 1, 2 and 3 (each within the scatter of the next).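

Methoxy in place of hydrogen on an aromatic carbon, ortho to a methoxy group and meta to a large group, gives in this assay a number 7 percentage points higher from compound 1 to compound 3 (within the scatter), so this position takes the added methoxy with no step beyond the scatter. This is a second change to the core of compound 1 that stays within the scatter, now on an aromatic carbon rather than on the carbonyl carbon. Nothing available explains the result.

Open, on these data alone, is whether an amine or a carboxylic acid at this position would give a step beyond the scatter. Also open, as far as these compounds go, is how a longer alkoxy chain would read here.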